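The source may hold more compounds than are shown below. What is called first, only, known or untested is meant among the compounds shown, and "the series" means these compounds.

The measured compounds and their values:
Compound 1, `CCC[C@@H](OC(C)=O)C1=C(Br)[C@@](OC)(C(Br)Br)OC1=O`: 3.9 ug/mL
Compound 2, `CCCCC1=C(Br)C(OC)(C(Br)Br)OC1=O`: 10.5 ug/mL
Compound 3, `CCC[C@@H](O)C1=C(Br)/C(=C\Br)OC1=O`: 0.2 ug/mL

In a functional assay on KB cells (Homo sapiens) for cytotoxicity (a higher number here means that more compound is needed for the effect, a lower number that less compound is needed), compound 3 gives 0.2 ug/mL, the lowest of the three numbers. Compound 1 gives 3.9 ug/mL, the nearest of the other two, yet a gap beyond the scatter, and compound 2 gives 10.5 ug/mL, the furthest away. Among the measured compounds shown here, compound 4, `CCC[C@@H](O)C1=C(Br)/C(=C/Br)OC1=O`, has not yet been tested in this assay. the two compounds have the same atoms and bonds and differ only in configuration as drawn: 1 of 2 stereo elements differ; a double bond is drawn E in compound 3 and Z in compound 4 No pair of measured compounds isolates a change of this kind, so no measured step anchors the expectation. A modest rise that may stay within the scatter is expected, a 2.0-fold higher number from compound 3 to compound 4 (0.30 log units; within the scatter). Compound 4 is therefore estimated at 0.4 ug/mL, with a range from 0.1 ug/mL to 1.5 ug/mL.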

Compound 4, concentration for half-maximal effect: 3.4 ug/mL
For compound 4 the middle estimate is 8.5-fold (0.93 log units) below the measured one; measured number outside the range, above it.
By their numbers in this assay, from the lowest: compound 3; then compounds 4 and 1 (each within the scatter of the next); then compound 2.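

In this assay, turning the double bond from E to Z brings a 17-fold higher number from compound 3 to compound 4 (1.23 log units; beyond the scatter), a large step beyond the scatter. Among the compounds shown here, none of the earlier compounds formed a pair differing in one place, so this is the first sign that the geometry at this double bond matters. The step can be assigned to that geometry alone: the fact that compounds 3 and 4 differ only in the configuration as drawn.

Going by these compounds, whether the E form keeps its lead with a longer chain in place of the present one remains open. So does the effect of an amine in place of the hydroxyl, or of chlorine in place of the bromine on the double bond.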